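The compounds below may be only part of what the source reports. "The series", "measured", "known", "first", "only" and "open" are said of these compounds alone.

Three compounds share one core and differ only in the chain on the aromatic nitrogen. Compound 1 `COC(=O)c1c(F)cccc1-c1ccc(CCc2ncc(CC(C)(C)C)n2CCC(=O)O)cc1` carries a carboxy group two bonds along that chain, and in an assay on cells for agonist activity at Bombesin receptor subtype-3 (Homo sapiens), read by HTRF and inositol phosphate accumulation, with a stated time of 1 h (a higher number here means that more compound is needed for the effect, a lower number that less compound is needed), compound 1 gives 1 nM. Compound 2 `COC(=O)c1c(F)cccc1-c1ccc(CCc2ncc(CC(C)(C)C)n2Cc2ccc(C(=O)O)cc2)cc1` carries a 4-carboxyphenyl group there, and compound 2 gives 3 nM. Compound 3 `COC(=O)c1c(F)cccc1-c1ccc(CCc2ncc(CC(C)(C)C)n2CCO)cc1` has a hydroxy group in place of the carboxy, and compound 3 gives 21 nM, the highest of the three numbers: the steps of a 21-fold higher number from compound 1 to compound 3 (1.32 log units; beyond the scatter) and a 7.0-fold higher number from compound 2 to compound 3 (0.85 log units; beyond the scatter) both lie beyond the scatter, while the step of a 3.0-fold higher number from compound 1 to compound 2 (0.48 log units; beyond the scatter) is smaller.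

Compound 4 `COC(=O)c1c(F)cccc1-c1ccc(CCc2ncc(CC(C)(C)C)n2CCOc2cccc(O)c2)cc1` is compound 3 with 3-hydroxyphenyl in place of hydrogen on an oxygen on a saturated carbon. Among the compounds with values here, no measured step makes this same change. Within the data shown here, the steps into compound 3 show only that a carboxy group, or a larger group on this chain, goes with a lower number than the bare hydroxy. A modest step downward is therefore expected, a 2.1-fold lower number from compound 3 to compound 4 (0.32 log units; beyond the scatter). The estimate for compound 4 is 10 nM, with a range from 3 nM to 40 nM.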

Compound 4, half-maximal effective concentration: 13 nM
Compound 4: middle estimate off by 1.3-fold (0.11 log units), on the low side; the range from low to high includes it.
By their numbers in this assay, from the lowest: compound 1; then compound 2; then compounds 4 and 3 (each within the scatter of the next).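

Putting 3-hydroxyphenyl on the oxygen of compound 3 adds a whole aromatic ring, yet in this assay the result stays within the scatter (a 1.6-fold lower number from compound 3 to compound 4 (0.21 log units; within the scatter)), so the assay cannot tell these two compounds apart. Large size alone does not match the carboxy compounds, since compound 2 also has a large group with a ring on this chain and still differs clearly from the 2-(3-hydroxyphenoxy)ethyl chain (a 4.3-fold higher number from compound 2 to compound 4 (0.64 log units; beyond the scatter)), as does the short carboxy chain of compound 1 (a 13-fold higher number from compound 1 to compound 4 (1.11 log units; beyond the scatter)). Nothing measured here explains any of these steps.

From the compounds shown here alone, it remains open whether the ring hydroxy matters at all, which plain phenoxy would test, or whether a carboxylic acid in its place would restore the lower numbers. A longer chain to the ring oxygen is equally untested in these compounds.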